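Changing the fused ring group on a carbonyl carbon

The source may report more compounds than this note shows. Statements on the series, on what has been measured and on what is new or still open speak of the compounds shown alone.

Compound 1 `Cc1ccccc1S(=O)(=O)c1ccc(CNC(=O)c2cc3cnccc3[nH]2)cc1` – 13 nM
Compound 2 `O=C(NCc1ccc(S(=O)(=O)c2ccccc2)cc1)c1nc2cnccc2[nH]1` – 5400 nM
Compound 3 `O=C(NCc1ccc(S(=O)(=O)c2ccccc2)cc1)c1cc2ccncc2s1` – 14 nM
Compound 4 `O=C(NCc1ccc(S(=O)(=O)c2ccccc2)cc1)c1cc2ncccc2s1` – not yet measured

In a functional assay on A2780 cells (Homo sapiens) for inhibition, read by sulforhodamine B assay, with a stated time of 72 h (a higher number here means a weaker inhibitor, a lower number a stronger inhibitor), compound 2 gives the highest of the three numbers, and the other two compounds both lie well beyond the scatter from it. Compound 4 differs from compound 2 by a group of 9 heavy atoms (7 carbon, 1 nitrogen, 1 sulfur; one five-membered aromatic ring with 1 hetero atom, one six-membered aromatic ring with 1 hetero atom) in place of a group of 9 heavy atoms (6 carbon, 3 nitrogen; one five-membered aromatic ring with 2 hetero atoms, one six-membered aromatic ring with 1 hetero atom), on a carbonyl carbon and in nothing else.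

For the measured compounds named here, one measured step bears directly on this change (a 390-fold lower number from compound 2 to compound 3 (2.59 log units; beyond the scatter)) and it is large. The group entering in compound 3 has the same counts as the group entering in compound 4, so that step sets the expected direction towards a lower number. The two entering groups are still not the same group. Their ring atoms are arranged differently. Going by the values given here, no measured compound shows what that difference in arrangement does, so the full size of the step cannot simply be carried over, and the range has to stay wide.

The expected step is a 27-fold lower number from compound 2 to compound 4 (1.43 log units; beyond the scatter) and it is expected to be smaller than the measured one. The estimate for compound 4 is 200 nM and the expected range runs from 15 nM to 3000 nM on the same read-out.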

Compound 4, half-maximal inhibitory concentration: > 10000 nM
Compound 4 gave a limit, no number; the forecaster's own chance of this, stated with the estimate: 5%; at least 50-fold (1.69 log units) between middle value and limit.
By their numbers in this assay, from the lowest: compounds 1 and 3 (each within the scatter of the next); then compound 2. At a limit, above all of these: compound 4.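

In this assay compound 4 stands at a limit of the assay and not at a number: the limit of > 10000 nM in this assay, at which 1 of the 4 values shown sits.

Compound 3 and compound 4 carry entering groups with the same counts on the carbonyl carbon, yet the arrangement of the ring atoms alone makes a large difference, an at least 710-fold higher number from compound 3 to compound 4 (2.85 log units; beyond the scatter), so the counts of a fused group say little at this position. The comparison with the starting compound is less sharp, as an at least 1.8-fold higher number from compound 2 to compound 4 (0.26 log units; that floor lies within the scatter) has a floor that does not separate the two, and the large gain seen in a 390-fold lower number from compound 2 to compound 3 (2.59 log units; beyond the scatter) therefore belongs to the particular group of compound 3 and not to every group with those counts.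

The compounds shown leave open how far compound 4 lies past its limit, and which part of the change in ring arrangement carries the step from compound 3. They also leave open what an amine or a carboxylic acid on the six-membered aromatic ring of the fused group would do to the number in this assay.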